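Swapping an Acyl Sulfonamide for a Carboxymethoxy Group

The source may report more compounds than this note shows. Statements on the series, on what has been measured and on what is new or still open speak of the compounds shown alone.

Of the compounds shown here, three built on one shared core have been tested in a functional assay on HEK293 cells for agonist activity at Bile acid receptor (Homo sapiens); a lower number here means that less compound is needed, a higher number that more compound is needed for the effect. Compound 1 `CC(C)c1onc(-c2c(Cl)cccc2Cl)c1COc1ccc(N(C)C(=O)c2ccc(C(=O)O)cc2)c(C(F)(F)F)n1` gives 316 nM in this assay. Compound 2 `CC(C)c1onc(-c2c(Cl)cccc2Cl)c1COc1ccc(N(C)Cc2ccc(CCC(=O)O)cc2)c(C(F)(F)F)n1` gives 35 nM, the step being a 9.0-fold lower number from compound 1 to compound 2 (0.96 log units; beyond the scatter). Compound 3 `CC(C)c1onc(-c2c(Cl)cccc2Cl)c1COc1ccc(N(C)Cc2ccc(C(=O)NS(C)(=O)=O)cc2)c(C(F)(F)F)n1` gives 221 nM, after a step of a 6.3-fold higher number from compound 2 to compound 3 (0.80 log units; beyond the scatter). Compound 3 thus sits close to compound 1, the two numbers lying within the usual scatter of each other, and well above compound 2.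

Compound 4 `CC(C)c1onc(-c2c(Cl)cccc2Cl)c1COc1ccc(N(C)Cc2ccc(OCC(=O)O)cc2)c(C(F)(F)F)n1` has not yet been measured. It differs from compound 3 in a single place: carboxymethoxy in place of (methylsulfonyl)carbamoyl on an aromatic carbon. The incoming group is again a carboxylic acid on a short chain, as in compound 2, so the two measured steps both bear on this change: the acid-bearing compound 2 gave the lowest number of the three, and replacing its acid chain by the acyl sulfonamide raised the number by a modest amount. A modest move back down is expected, a 4.4-fold lower number from compound 3 to compound 4 (0.65 log units; beyond the scatter). For compound 4 the estimate is 50 nM, with a likely range from 20 nM to 150 nM.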

Compound 4, half-maximal effective concentration: 214 nM
Compound 4: middle estimate off by 4.3-fold (0.63 log units), on the low side; measured number outside the range, above it.
By their numbers in this assay, from the lowest: compound 2; then compounds 4, 3 and 1 (each within the scatter of the next).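

In this assay, a carboxylic acid on a short chain does not by itself bring the number down: at this aromatic carbon, carboxymethoxy and (methylsulfonyl)carbamoyl cannot be told apart (a 1.0-fold lower number from compound 3 to compound 4 (0.01 log units; within the scatter)). The low number of compound 2 is therefore tied to 2-carboxyethyl in particular and not to any short acid chain, since changing that group to carboxymethoxy, which also ends in a carboxylic acid, costs a clear step (a 6.1-fold higher number from compound 2 to compound 4 (0.79 log units; beyond the scatter)). Compound 4 also cannot be told apart from the carbonyl-linked compound 1 (a 1.5-fold lower number from compound 1 to compound 4 (0.17 log units; within the scatter)), so compound 2 alone stands apart among the four.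

The compounds shown leave open how a longer carboxylic acid chain, or an amine at this carbon, would read. Nothing available here explains the gap between 2-carboxyethyl and carboxymethoxy.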